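Furan-3-ylmethylamine replaces the phenylethylamine arm

This account rests on a few compounds, and the source may have more. Where it says the series, first, only, none or still open, it means among the compounds named here.

The three measured compounds share one core and differ only in the arm carried by the saturated ring. Compound 1 `CN(CC1CCN(CCCc2c[nH]c3ccc(-n4cnnc4)cc23)CC1)C(=O)Nc1ccccc1` gives 6.2 nM in an assay on CHO cells for displacement of a labelled ligand from 5-hydroxytryptamine receptor 1B (Homo sapiens) (on this read-out lower numbers stand for stronger inhibition and higher numbers for weaker inhibition), compound 2 `C[C@@H](NCC1CCN(CCCc2c[nH]c3ccc(-n4cnnc4)cc23)CC1)c1ccccc1` gives 14 nM and compound 3 `CC(=O)Nc1ccc([C@@H](C)NCC2CCN(CCCc3c[nH]c4ccc(-n5cnnc5)cc34)CC2)cc1` gives 8.9 nM. Compound 2 stands at the highest number of the three: the step from compound 1 is a 2.3-fold higher number from compound 1 to compound 2 (0.35 log units; beyond the scatter), whereas the step to compound 3, a 1.6-fold lower number from compound 2 to compound 3 (0.20 log units; within the scatter), lies within the scatter, so compound 2 and compound 3 cannot be told apart.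

Compound 4 `c1cc(CNC2CCN(CCCc3c[nH]c4ccc(-n5cnnc5)cc34)CC2)co1` is not yet measured. It differs from compound 2 in ((furan-3-yl)methyl)amino in place of ((1-phenylethyl)amino)methyl on a saturated ring carbon. Among the compounds with values here, no measured step covers this exact change. Within the data shown here, the only step beyond the scatter, from compound 1 to compound 2, shows that swapping the whole arm moves the number modestly, while adding acetamido to the aromatic ring did little. Compound 4 is therefore expected to sit near compound 2, with a step of a 1.6-fold higher number from compound 2 to compound 4 (0.20 log units; within the scatter) toward a somewhat weaker number. The estimate for compound 4 in this assay is 22 nM, within 7 nM to 70 nM.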

Compound 4, half-maximal inhibitory concentration: 78 nM
Compound 4: middle estimate off by 3.5-fold (0.55 log units), on the low side, and the stated range ends below it.
By their numbers in this assay, from the lowest: compounds 1, 3 and 2 (each within the scatter of the next, the first and the last beyond it); then compound 4.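

Unlike the earlier arm swap, this change on the saturated ring carbon moves the number well beyond the scatter in this assay, with a 5.6-fold higher number from compound 2 to compound 4 (0.75 log units; beyond the scatter), so the binding read-out is clearly sensitive to the arm here. Within the data shown here, the step is larger than the one between compound 1 and compound 2, showing that the series does not tolerate every arm equally. The change is a bundled one, however: the six-membered aromatic ring of carbon only gives way to a five-membered aromatic ring with one hetero atom, the heavy-atom count falls, and the defined stereocentre is lost. Nothing available explains the size of this step.

The compounds shown cannot assign the loss to any one of these differences. A ((benzyl)amino)methyl arm or a (((furan-3-yl)methyl)amino)methyl arm on the same ring carbon would separate the effect of the ring from that of the rest of the arm.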